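Fluoro on the Shared Core: From Compound 2 to Compound 3

The compounds below may be only part of what the source reports. "The series", "measured", "known", "first", "only" and "open" are said of these compounds alone.

Compound 2 `CC1(CO)OC[C@@H](n2ccc(N)nc2=O)O1` was examined in a functional assay on B16-F10 cells (Mus musculus) for inhibition; on this read-out higher numbers stand for weaker inhibition and lower numbers for stronger inhibition. In this assay compound 2 gives only a limit, > 100000 nM, and not a number. Compound 1 `C[C@]1(CO)OCC(n2cc(F)c(N)nc2=O)O1` was examined too. In this assay compound 1 likewise reaches only a limit, > 100000 nM. For the measured compounds named here, both results therefore sit at the limit of > 100000 nM in this assay, at which 2 of the 2 values shown sit, so no measured step between the two compounds can be stated. Compound 3 `CC1(CO)OC[C@@H](n2cc(F)c(N)nc2=O)O1` has not been measured. It differs from compound 2 by fluoro in place of hydrogen on an aromatic carbon, ortho to an amino group and two atoms from the ring nitrogen. Compound 1 carries the same fluoro and, as noted, reached only a limit. The step from compound 2 to compound 3 is expected to be a number no higher from compound 2 to compound 3 (the limit leaves the size open), none beyond the scatter. Compound 3 is estimated at 100000 nM, within 30000 nM to 300000 nM, and most likely reported again as a limit.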

Compound 3, half-maximal inhibitory concentration: > 100000 nM
Compound 3: a limit, no number; the forecaster's own chance of this, stated with the estimate: 85%; the middle value lies on the limit itself.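

For the compounds shown here, compound 3 also reaches only a limit, > 100000 nM, so no step to it from compound 1 or compound 2 can be read: the limit of > 100000 nM in this assay, at which 3 of the 3 values shown sit. The compounds shown leave open whether fluoro in place of hydrogen, or the drawn configuration, alters inhibition at all.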